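Shortening the Amine Chain Back Toward Compound 1

A few compounds are considered here, and "the series" means these few. Any claim that something is new, unique, unknown or untested is made for them only; others in the source may bear on it.

Compound 1, `CN(C)Cc1nnc(-c2ccccc2-c2ccccc2)s1`, in a functional assay on the whole organism with Mus musculus as the target (on this read-out higher numbers stand for an effect only at larger amounts of compound and lower numbers for an effect already at smaller amounts), gives 32 mg/kg.
Compound 2, `NCCCc1nnc(-c2ccccc2-c2ccccc2)s1`, reached only the limit (the limit of > 200 mg/kg in this assay, at which 1 of the 2 values shown sits), recorded as > 200 mg/kg.

Compound 2 thus stands at the edge of what the measurement can show: the step of an at least 6.2-fold higher number from compound 1 to compound 2 (0.79 log units; beyond the scatter) says its number is at least that much higher than that of compound 1. Compound 3, `CNCc1nnc(-c2ccccc2-c2ccccc2)s1`, differs from compound 2 by methylamino in place of 2-aminoethyl on a saturated chain carbon bound to an aromatic carbon. Compound 3 and compound 1 differ only by one methyl on the nitrogen. Compound 3 is therefore expected to land near compound 1, an expected step of an at least 4.4-fold lower number from compound 2 to compound 3 (0.64 log units; beyond the scatter) toward lower numbers. The estimate for compound 3 is 45 mg/kg, between 15 mg/kg and 150 mg/kg.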

Compound 3, dose for half-maximal effect: 25 mg/kg
Compound 3: the middle estimate sits 1.8-fold (0.26 log units) above what was measured; the range from low to high includes it.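

Replacing 2-aminoethyl with methylamino at this saturated chain carbon restores an effect at smaller doses, with an at least 8.0-fold lower number from compound 2 to compound 3 (0.90 log units; beyond the scatter). The value for compound 2 remains a limit and not a number: the limit of > 200 mg/kg in this assay, at which 1 of the 3 values shown sits. On the amine nitrogen, the methyl can be replaced by hydrogen without a difference beyond the scatter, with a 1.3-fold lower number from compound 1 to compound 3 (0.11 log units; within the scatter).

Compound 2 and compound 3 differ in both chain length and the substituent on nitrogen, so the compounds shown do not separate these two changes. An aminomethyl group or a 3-(dimethylamino)propyl group in the same place would bear on that question.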